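A few compounds are considered here, and "the series" means these few. Any claim that something is new, unique, unknown or untested is made for them only; others in the source may bear on it.

Compound 1 `COc1ccc(C2CC(c3ccccc3)=NN2C2=NC(=O)/C(=C3\C(=O)Nc4ccccc43)S2)cc1` and compound 2 `COc1ccc(C2CC(c3ccccc3)=NN2C2=NC(=O)/C(=C3\C(=O)Nc4ccc(Br)cc43)S2)cc1` share one core and differ in a single spot: bromo in place of hydrogen on an aromatic carbon. In a functional assay on cells (Cancer cell lines, Homo sapiens) for cytotoxicity, read by sulforhodamine B assay, with a stated time of 48 h (a higher number here means a weaker inhibitor of growth, a lower number a stronger inhibitor of growth), compound 1 gives 4390 nM, while compound 2 gives 390 nM, so the bromo on that ring brought a large gain, an 11-fold lower number from compound 1 to compound 2 (1.05 log units; beyond the scatter).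

Compound 3 `COc1ccc(C2=NN(C3=NC(=O)/C(=C4\C(=O)Nc5ccccc54)S3)C(c3ccc(Cl)cc3)C2)cc1` is built on a different core; how the two cores differ is not broken down here. In this assay compound 3 gives 100000 nM, the highest number among the three measured compounds and well apart from both compound 1 and compound 2.

Compound 4 `COc1ccc(C2=NN(C3=NC(=O)/C(=C4\C(=O)Nc5ccc(Br)cc54)S3)C(c3ccc(Cl)cc3)C2)cc1` carries the same change on the core of compound 3: bromo in place of hydrogen on an aromatic carbon. The place of the entering bromo is described in the same words for both pairs, so this is the same change made a second time. Among the compounds with values here, the only guide to its size is the single earlier step from compound 1 to compound 2. On that basis a drop of a similar size is expected for compound 4, an 8.3-fold lower number from compound 3 to compound 4 (0.92 log units; beyond the scatter), though a core that differs in an unresolved way and a starting number as high as that of compound 3 leave this uncertain. The estimated value for compound 4 in this assay is 12000 nM, with a plausible range from 2500 nM to 60000 nM.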

Compound 4, concentration for total growth inhibition: 7440 nM
Compound 4: the middle estimate sits 1.6-fold (0.21 log units) above what was measured; low and high end bracket the measured number.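

In this assay, bromo in place of hydrogen on an aromatic carbon again brought a large gain, a 13-fold lower number from compound 3 to compound 4 (1.13 log units; beyond the scatter). Set beside the same change on the other core, the gain carried over at much the same size, even though the two cores start from very different numbers: the same change on two cores in this assay, an 11-fold lower number (1.05 log units; beyond the scatter) from compound 1 to compound 2 and a 13-fold lower number (1.13 log units; beyond the scatter) from compound 3 to compound 4, 1.2-fold (0.08 log units) apart, within the scatter of two such steps This shows that, for these two pairs of compounds and in this one test on cancer cells, the effect of the bromo held when the core changed, but it does not show why the bromo lowers the number, nor that a third core would behave in the same way, since two pairs are a small base for any rule.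

The compounds shown compare only bromo with hydrogen at this one place, so it remains open whether a fluoro group, a nitro group or an amine there would bring a step of similar size. Going by these compounds, it also remains open whether bromo on another aromatic carbon of that ring would repeat the gain on either core.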